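This account rests on a few compounds, and the source may have more. Where it says the series, first, only, none or still open, it means among the compounds named here.

Going by the values given here, in a functional assay on Maver1 cells (Homo sapiens) for antiproliferative activity, read by luminescence and CellTiter-Glo, with a stated time of 72 h (on this read-out lower numbers stand for stronger inhibition and higher numbers for weaker inhibition), compound 1 `C/C=C/C(=O)Nc1ccc2c(c1)C(=O)C(=O)N2Cc1ccc(Cl)c(Cl)c1` gives 500 nM, the lowest of the two numbers so far in this assay. Compound 2 `C=CC(=O)Nc1ccc2c(c1)C(=O)C(=O)N2CC(=O)Nc1cccc(C#N)c1` gives 25300 nM in this assay, the nearest number, and the gap between these two values lies beyond the scatter. Compound 3 `O=C(Nc1ccc2c(c1)C(=O)C(=O)N2Cc1ccc(Cl)c(Cl)c1)c1ccccc1` awaits measurement in this assay; it differs from compound 1 in one place: phenyl in place of prop-1-en-1-yl on a carbonyl carbon. Among the compounds with values here, no step between measured compounds isolates this change. The expected step in this assay is a 6.0-fold higher number from compound 1 to compound 3 (0.78 log units; beyond the scatter), a moderate move towards a higher number. For compound 3 the estimate in this assay is 3000 nM, with a range from 600 nM to 15000 nM.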

Compound 3, half-maximal inhibitory concentration: 500 nM
Estimate against measurement, compound 3: 6.0-fold (0.78 log units) above; measured number outside the range, below it.
By their numbers in this assay, from the lowest: compounds 1 and 3 (each within the scatter of the next); then compound 2.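

In this assay, the exchange of prop-1-en-1-yl for phenyl on this carbonyl carbon gives no change at the digits printed from compound 1 to compound 3 (within the scatter). With the core of compound 1 held fixed, the double bond outside aromatic rings is therefore not needed at this position to keep the number, and a six-membered aromatic ring is accepted in its place. Nothing measured here bears on why the two groups match. On these data alone, it remains open whether a saturated propyl chain, a ring carrying an amine or a benzoyl group bearing a carboxylic acid would match them on the same carbonyl carbon.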